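A Dichlorobenzoyl Ester in Place of an Acetate

A few compounds are considered here, and "the series" means these few. Any claim that something is new, unique, unknown or untested is made for them only; others in the source may bear on it.

Of the compounds shown here, three sharing one core have been tested in a functional assay on MDA-MB-231 cells (Homo sapiens) for antiproliferative activity, read by MTT assay, with a stated time of 72 h; on this read-out lower numbers stand for stronger inhibition and higher numbers for weaker inhibition. Compound 1 `CC1=CC[C@H]2[C@@H]1CC=C(C)[C@@H](CCC1=C(C)CC[C@@H]3OC(C)(C)[C@@H](O)CC[C@@]13C)C2(C)C` carries no substituent at the oxygen of interest, and in this assay compound 1 reaches only the limit of > 50000 nM, so no number is known for it. Compound 2 `CC(=O)O[C@H]1CC[C@]2(C)[C@H](CC[C@@](C)(O)[C@H]2CC[C@@H]2C(C)=CC[C@H]3[C@H](CC[C@]3(C)O)C2(C)C)OC1(C)C` bears an acetyl ester at that oxygen, and in this assay compound 2 gives 38000 nM. Compound 3 `CC1=CC[C@H]2[C@@H]1CC=C(C)[C@@H](CC[C@H]1[C@]3(C)CC[C@H](OCc4ccccc4)C(C)(C)O[C@H]3CC[C@@]1(C)O)C2(C)C` has a benzyl ether there instead, and in this assay compound 3 gives 35700 nM. Among the two compounds with numbers, compound 2 stands highest, but its gap to compound 3 lies within the scatter of repeated measurements, so the two cannot be told apart.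

Compound 4 `CC1=CC[C@H]2[C@H](CC[C@]2(C)O)C(C)(C)[C@@H]1CC[C@H]1[C@]2(C)CC[C@H](OC(=O)c3ccc(Cl)c(Cl)c3)C(C)(C)O[C@H]2CC[C@@]1(C)O` has not yet been measured. It differs from compound 2 as follows: 3,4-dichlorophenyl in place of methyl on a carbonyl carbon. Going by the values given here, no measured pair shows this change, so its effect must be guessed from the weak values of compound 2 and compound 3, which sit close together despite different groups on the same oxygen. A step no larger than the scatter is expected, with compound 4 estimated to give 28000 nM, between 9000 nM and 70000 nM; the expected change from compound 2 to compound 4 is a 1.4-fold lower number from compound 2 to compound 4 (0.13 log units; within the scatter).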

Compound 4, half-maximal inhibitory concentration: 8100 nM
Beside the measured number, compound 4's estimate is 3.5-fold (0.54 log units) above it; measured number outside the range, below it.
By their numbers in this assay, from the lowest: compound 4; then compounds 3 and 2 (each within the scatter of the next). At a limit, above all of these: compound 1.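

In this assay, putting 3,4-dichlorophenyl in place of methyl on a carbonyl carbon gives a 4.7-fold lower number from compound 2 to compound 4 (0.67 log units; beyond the scatter), a modest step, but the only one in this set that can be read as a real difference. Compound 2 and compound 3 lie within the scatter of each other, so they gave no sign that the group on this oxygen affects the read-out, whereas compound 4 shows that this position does respond to a change. Compound 1 stands at a limit of the assay rather than at a number, so no step to it can be read: the limit of > 50000 nM in this assay, at which 1 of the 4 values shown sits.

The change brings in an aromatic ring and two chlorine atoms together, so the compounds shown cannot say which of these goes with the lower number; a plain benzoyl ester, with no chlorine on its ring, would separate the two. Also open, going by these compounds, is whether the ester link itself matters, a question that a benzyl ether carrying the same 3,4-dichlorophenyl group could address.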